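Chain-extended aryl ureas in a rice activity assay

A few compounds are considered here, and "the series" means these few. Any claim that something is new, unique, unknown or untested is made for them only; others in the source may bear on it.

Measured so far:
compound 1, `CCc1ccc(NC(=O)N[C@@H](C)c2ccccc2)cc1`: 91%
compound 2, `CCCCc1ccc(NC(=O)N[C@@H](C)c2ccccc2)cc1`: 60%

In an ADME assay on the whole organism with Oryza sativa as the target, tested at 10 uM (a lower number here means a stronger effect, a higher number a weaker effect of the compound at the concentration tested), compound 1 gives 91% and compound 2 gives 60%. Compound 2 stands lowest of the two numbers; its nearest neighbour is compound 1, and the step of a number 31 percentage points lower from compound 1 to compound 2 (beyond the scatter) lies beyond the scatter. Compound 3, `CCCCCc1ccc(NC(=O)N[C@@H](C)c2ccccc2)cc1`, carries the change methyl in place of hydrogen on a saturated chain carbon, four bonds along the chain from an aromatic carbon relative to compound 2. Going by the values given here, the only step that bears on this change is the chain extension from compound 1 to compound 2, which was large and downward in this assay. The change to compound 3 adds one carbon to the same chain, so a further drop is expected, though smaller than the two-carbon step. The expected step is a number 15 percentage points lower from compound 2 to compound 3 (beyond the scatter). For compound 3 the estimate in this assay is 45%, with a range from 25% to 65%.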

Compound 3, a percentage reported as activity, at one concentration (the size of the read-out at that concentration, not a potency): 93%
Estimate against measurement, compound 3: 48 percentage points below, outside the stated range (above it).
By their numbers in this assay, from the lowest: compound 2; then compounds 1 and 3 (each within the scatter of the next).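

In this assay, methyl in place of hydrogen on a saturated chain carbon, four bonds along the chain from an aromatic carbon, reverses the direction seen with the earlier chain extension, giving a number 33 percentage points higher from compound 2 to compound 3 (beyond the scatter). Measured against the shorter chain, the longer chain gives a number 2 percentage points higher from compound 1 to compound 3 (within the scatter), so compound 2 alone stands apart, and compound 3 goes against any pattern of lower numbers with longer chains. Nothing measured here accounts for this reversal.

Open, as far as these compounds go, is whether the low number of compound 2 marks a narrow optimum in chain length or an isolated value. Also open, from the compounds shown here alone, is how a propyl group, a hexyl chain or a chain ending in a hydroxyl group would read at this position.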